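Benzyl-substituted nucleosides: antiproliferative series notes

A few compounds are considered here, and "the series" means these few. Any claim that something is new, unique, unknown or untested is made for them only; others in the source may bear on it.

The series shares one core, seen in compound 1 `OC[C@H]1O[C@@H](n2cnc3c(NCc4ccccc4Cl)ncnc32)[C@H](O)[C@@H]1O`, compound 2 `OC[C@H]1O[C@@H](n2cnc3c(NCc4cccc(Br)c4)ncnc32)[C@H](O)[C@@H]1O` and compound 3 `Cc1ccc(CNc2ncnc3c2ncn3[C@@H]2O[C@H](CO)[C@@H](O)[C@H]2O)cc1`. In a functional assay on MCF cells (Homo sapiens) for antiproliferative activity, with a stated time of 72 h (a higher number here means a weaker inhibitor, a lower number a stronger inhibitor), compound 1 reaches only the assay limit, > 166000 nM. Compound 2 likewise stands at a limit in this assay, > 166000 nM. Compound 3 also gives only a limit in this assay, > 166000 nM. Hence a step that the two limits leave unreadable from compound 1 to compound 2, a step that the two limits leave unreadable from compound 1 to compound 3 and a step that the two limits leave unreadable from compound 2 to compound 3 stay unreadable, all three values sitting at the limit of > 166000 nM in this assay, at which 3 of the 3 values shown sit. Compound 4 `OC[C@H]1O[C@@H](n2cnc3c(NCc4ccc(C(F)(F)F)cc4)ncnc32)[C@H](O)[C@@H]1O` arises from compound 2 by 4-(trifluoromethyl)phenyl in place of 3-bromophenyl on a saturated chain carbon bound to a nitrogen on an aromatic ring. Within the data shown here, no measured step gives a readable size for such a change, so for compound 4 in this assay the expected outcome is again a limit rather than a number. The estimate for compound 4 is 166000 nM, range 50000 nM to 500000 nM, meaning an expected step of a number no higher from compound 2 to compound 4 (the limit leaves the size open).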

Compound 4, half-maximal inhibitory concentration: > 166000 nM
Compound 4: no number, only a limit; the forecaster's own chance of this, stated with the estimate: 85%; the middle value sits exactly at the limit.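

Compound 4 gives only a limit in this assay, > 166000 nM, so no step linking it with compound 1, compound 2 or compound 3 can be read: the limit of > 166000 nM in this assay, at which 4 of the 4 values shown sit.

The compounds shown leave open whether any aromatic group at this place on the shared core gives a number rather than a limit.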